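Hydroxy in Place of Tert-Butyl on the Amide Nitrogen

This account rests on a few compounds, and the source may have more. Where it says the series, first, only, none or still open, it means among the compounds named here.

Compound 1 `CCN(Cc1ccco1)C(=O)COc1ccc(C)cc1` gives 489 nM in an assay on HEK293 cells for agonist activity at transient receptor potential cation channel subfamily M member 8 (Homo sapiens), read by fluorescence and calcium flux, with a stated time of 15 min; a lower number here means that less compound is needed, a higher number that more compound is needed for the effect.
Compound 2 `Cc1ccc(OCC(=O)N(Cc2cccs2)C(C)(C)C)cc1` gives 11000 nM in this assay.
Compound 3 `COc1ccc(OCC(=O)N(Cc2cccs2)c2ccn[nH]2)cc1` gives 3.7 nM in this assay.

Compound 2 has the highest number of the three, beyond the scatter from compound 1 and further still from compound 3, so more of it is needed than of either. Compound 4 `Cc1ccc(OCC(=O)N(O)Cc2cccs2)cc1` differs from compound 2 in one place: hydroxy in place of tert-butyl on an amide-type nitrogen. Among the compounds with values here, no measured pair shows this change, so its size can only be guessed. Since compound 1 carries a smaller group on the same nitrogen and gives 489 nM, a step downward in this assay is expected for compound 4, though of uncertain size. The expected step is a 4.4-fold lower number from compound 2 to compound 4 (0.64 log units; beyond the scatter). Compound 4 is estimated at 2500 nM, between 300 nM and 20000 nM.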

Compound 4, half-maximal effective concentration: 8000 nM
Beside the measured number, compound 4's estimate is 3.2-fold (0.51 log units) below it; the measured number falls inside the stated range.
By their numbers in this assay, from the lowest: compound 3; then compound 1; then compounds 4 and 2 (each within the scatter of the next).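

On the amide-type nitrogen, hydroxy in place of tert-butyl gives a 1.4-fold lower number from compound 2 to compound 4 (0.14 log units; within the scatter) in this assay, so this exchange does not separate the two compounds. A group of 4 carbon atoms gives way to a single oxygen, and a hydrogen-bond donor and acceptor enter, yet the number stays within the scatter. The compounds shown leave open whether methoxy or an amine on this nitrogen, on the same core, would give a number apart from those of compound 2 and compound 4. No measurement shown here bears on why the exchange gives this result.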